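This account rests on a few compounds, and the source may have more. Where it says the series, first, only, none or still open, it means among the compounds named here.

Compound 1 `COc1cc(Nc2nc(C(=N)Nc3ccc(N4CCN(C)CC4)cc3)cc3c(-c4ccccc4)n[nH]c23)cc(OC)c1OC` gives 4600 nM in a functional assay on MDA-MB-231 cells (Homo sapiens) for cytotoxicity, read by MTT assay, with a stated time of 72 h; on this read-out lower numbers stand for stronger inhibition and higher numbers for weaker inhibition; compound 2 `COc1ccc(Cn2nc(-c3ccccc3)c3cc(C(=N)Nc4ccc(N5CCN(C)CC5)cc4)nc(Nc4cc(OC)c(OC)c(OC)c4)c32)cc1` gives 890 nM in this assay.

Compound 2 holds the lowest of the two numbers in this assay. Among the measured compounds shown here, the only measured step, a 5.2-fold lower number from compound 1 to compound 2 (0.71 log units; beyond the scatter), came with 4-methoxybenzyl in place of hydrogen on an aromatic nitrogen. Compound 3 `COc1ccc(Cn2nc(-c3ccccc3)c3cc(C(=N)Nc4ccccc4)nc(Nc4cc(OC)c(OC)c(OC)c4)c32)cc1` differs from compound 2 by hydrogen in place of 4-methylpiperazin-1-yl on an aromatic carbon. For the measured compounds named here, no measured step bears on this change, since the one step known concerns another position. The expected step from compound 2 to compound 3 is therefore a modest weakening, a 2.0-fold higher number from compound 2 to compound 3 (0.31 log units; beyond the scatter). Compound 3 is expected to give 1800 nM, within 600 nM to 6000 nM.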

Compound 3, half-maximal inhibitory concentration: 42100 nM
Compound 3: the middle estimate sits 23-fold (1.37 log units) below what was measured; the whole stated range lies below it.
By their numbers in this assay, from the lowest: compound 2; then compound 1; then compound 3.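

On the aromatic carbon para to a large group, the substituent carries much of the activity in this assay: hydrogen in place of 4-methylpiperazin-1-yl gives a 47-fold higher number from compound 2 to compound 3 (1.67 log units; beyond the scatter). Among the compounds shown here, this is a large step at a position that no earlier pair had tested. Nothing available accounts for the size of this loss.

As far as these compounds go, whether the whole 4-methylpiperazin-1-yl group is needed remains open. A morpholine, an unsubstituted piperazine or a simple dimethylamino group at this place would show which part of it counts.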